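Swapping Chloro for Acetoxy in a Growth Inhibitor

The compounds below may be only part of what the source reports. "The series", "measured", "known", "first", "only" and "open" are said of these compounds alone.

Of the compounds shown here, three have been measured so far in a functional assay on DU-145 cells (Homo sapiens) for inhibition, read by trypan blue exclusion, with a stated time of 96 h; a lower number here means a stronger inhibitor of growth, a higher number a weaker inhibitor of growth. There, compound 1 `COc1ccccc1/C=C(\C(=O)c1ccc(Br)cc1)S(=O)(=O)c1ccc(C)cc1` gives 1000 nM, compound 2 `Cc1ccc(S(=O)(=O)/C(=C/c2ccc(Cl)cc2)C(=O)c2ccc(Cl)cc2)cc1` gives 1000 nM, and compound 3 `O=C(O)c1ccc(C(=O)/C(=C\c2ccc(F)c([N+](=O)[O-])c2)SCc2ccc(C(F)(F)F)cc2)cc1` gives 1000 nM. Compound 2 therefore stands level with both of the others, and no gap between them goes beyond the usual scatter of repeated measurements.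

The next compound to be tested is compound 4 `CC(=O)Oc1ccc(/C=C(\C(=O)c2ccc(Cl)cc2)S(=O)(=O)c2ccc(C)cc2)cc1`. It differs from compound 2 at one place, with acetoxy in place of chloro on an aromatic carbon. Cut one bond further out, the same change reads 4-chlorophenyl to 4-acetoxyphenyl.

No two of the measured compounds differ in only one place, so the data hold no direct measure of what a single change does in this assay. Among the measured compounds shown here, the only guide is that structures as unlike as compound 2 at 1000 nM and compound 3 at 1000 nM read the same. On that thin basis, the expected step of no change at the digits printed from compound 2 to compound 4 (within the scatter) is none beyond the scatter, in either direction. Compound 4 is estimated at 1000 nM, with an expected range from 300 nM to 3000 nM.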

Compound 4, concentration for 50% growth inhibition: 25000 nM
Beside the measured number, compound 4's estimate is 25-fold (1.40 log units) below it; measured number above the stated range.
By their numbers in this assay, from the lowest: compounds 1, 2 and 3 (each within the scatter of the next); then compound 4.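

In this assay, putting acetoxy in place of chloro on an aromatic carbon gives a 25-fold higher number from compound 2 to compound 4 (1.40 log units; beyond the scatter), so the larger number marks a much weaker inhibitor of growth. Among the compounds shown here, this is the first comparison of compounds that differ in only one place, and it shows that the group on this six-membered aromatic ring, para to a large group, is not a free choice: this single exchange, from 4-chlorophenyl to 4-acetoxyphenyl, is enough to move the reading well past the usual scatter. Nothing measured here explains the loss, and the data give no cause for it.

The compounds shown leave open whether the loss goes with the whole acetoxy group or with only part of it, and a plain hydroxyl group or an amine at this same place would help to separate those two readings. Also open, on these data alone, is whether the same exchange would give a step of this size on a different core, such as that of compound 3, rather than only in this one pair.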